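Compound 3 to compound 4: 2-ethoxyethyl replaces oxan-4-yl

A few compounds are considered here, and "the series" means these few. Any claim that something is new, unique, unknown or untested is made for them only; others in the source may bear on it.

In an ADME assay on CEM-SS cells (Homo sapiens) for cytotoxicity, read by XTT assay (on this read-out higher numbers stand for lower toxicity in this test and lower numbers for higher toxicity in this test), compound 3 `CN(O)C(=O)c1cc2c(COC3CCOCC3)cn(Cc3ccc(F)cc3)c2cn1` gives > 100000 nM, which is a limit and not a number. Compound 1 `CN1CCN(Cc2cn(Cc3ccc(F)cc3)c3cnc(C(=O)N(C)O)cc23)CC1` gives > 224000 nM, also a limit. Compound 2 `CN(O)C(=O)c1cc2c(CN3CCNC(=O)C3)cn(Cc3ccc(F)cc3)c2cn1` gives > 100000 nM, again a limit. No measured value therefore places compound 3 more exactly. Compound 4 `CCOCCOCc1cn(Cc2ccc(F)cc2)c2cnc(C(=O)N(C)O)cc12` carries 2-ethoxyethyl in place of oxan-4-yl on an oxygen on a saturated carbon. The nearest evidence is a step that the two limits leave unreadable from compound 1 to compound 3 and a step that the two limits leave unreadable from compound 2 to compound 3, with a step that the two limits leave unreadable from compound 1 to compound 2 behind them, and none of these has a readable size. No change in either direction beyond the usual scatter is therefore expected, and the expected result is a number no higher from compound 3 to compound 4 (the limit leaves the size open). For compound 4 the estimated value is 100000 nM, with an expected range from 40000 nM to 250000 nM.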

Compound 4, half-maximal cytotoxic concentration: 81000 nM
Beside the measured number, compound 4's estimate is 1.2-fold (0.09 log units) above it; low and high end bracket the measured number.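

In this assay, within the data shown here, compound 4 gives 81000 nM, the first true number rather than a limit. Putting 2-ethoxyethyl in place of oxan-4-yl on this oxygen gives an at least 1.2-fold lower number from compound 3 to compound 4 (0.09 log units; that floor lies within the scatter), and the change from the 3-oxopiperazin-1-yl group gives an at least 1.2-fold lower number from compound 2 to compound 4 (0.09 log units; that floor lies within the scatter), so neither floor shows a change beyond the scatter. Only the change from the 4-methylpiperazin-1-yl group, an at least 2.7-fold lower number from compound 1 to compound 4 (0.44 log units; beyond the scatter), is shown to exceed it.

The steps among compounds 1, 2 and 3 still cannot be read. As far as these compounds go, whether a longer chain or a carboxylic acid on this oxygen would lower the number further remains open.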